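Removing a Chloro Group on Two Different Cores

The compounds below may be only part of what the source reports. "The series", "measured", "known", "first", "only" and "open" are said of these compounds alone.

Measured compounds:
Compound 1, `Cc1cc(Sc2cccc(Cl)c2)c(S(C)(=O)=O)cc1C(=O)N=C(N)N`: 37 nM
Compound 2, `Cc1cc(Sc2ccccc2)c(S(C)(=O)=O)cc1C(=O)N=C(N)N`: 14 nM
Compound 3, `CS(=O)(=O)c1cc(C(=O)N=C(N)N)c(Cl)cc1-n1ccnc1`: 130 nM

In a functional assay for inhibition of sodium/hydrogen exchanger (Oryctolagus cuniculus) (on this read-out lower numbers stand for stronger inhibition and higher numbers for weaker inhibition), compound 2 stands lowest and compound 3 highest; the difference between the core of compound 1 and the core of compound 3 is not broken down here. The step of a 2.6-fold lower number from compound 1 to compound 2 (0.42 log units; beyond the scatter) came from hydrogen in place of chloro on an aromatic carbon. The unmeasured compound 4, `CS(=O)(=O)c1cc(C(=O)N=C(N)N)ccc1-n1ccnc1`, differs from compound 3 by hydrogen in place of chloro on an aromatic carbon. This is the same kind of change as that from compound 1 to compound 2, not the same: there the chloro sat meta to a large group on the ring carrying the sulfanyl link, whereas here it sits ortho to a group of 6 heavy atoms, meta to a 1H-imidazol-1-yl group and para to a methylsulfonyl group on the core ring itself. Within the data shown here, only one earlier step of this kind is known, and it was modest, so compound 4 is expected to show a 1.2-fold lower number from compound 3 to compound 4 (0.07 log units; within the scatter), resting on the step from compound 1 to compound 2 but with wide uncertainty because the surroundings of the place differ. Compound 4 is thus estimated at 110 nM, between 40 nM and 330 nM.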

Compound 4, half-maximal inhibitory concentration: 150 nM
Compound 4: middle estimate off by 1.4-fold (0.13 log units), on the low side; low and high end bracket the measured number.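

In this assay, hydrogen in place of chloro on the second core gave a 1.2-fold higher number from compound 3 to compound 4 (0.06 log units; within the scatter), so here the change leaves the number within the scatter. The step seen on the first core therefore did not carry over to the second, and the two results differ by more than the scatter: the same change on two cores in this assay, a 2.6-fold lower number (0.42 log units; beyond the scatter) from compound 1 to compound 2 and a 1.2-fold higher number (0.06 log units; within the scatter) from compound 3 to compound 4, 3.0-fold (0.48 log units) apart, beyond the scatter of two such steps. This does not show which difference between the two pairs accounts for the gap, as the chloro stands in different surroundings in each pair and the cores differ too, and two pairs set no rule for any further core.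

The compounds shown leave open how the core of compound 4 would respond to a fluoro, a methoxy or an amine at the place that held the chloro, ortho to a group of 6 heavy atoms. From the compounds shown here alone, it is also open whether a hydroxyl or a carboxylic acid on the 1H-imidazol-1-yl group would alter the number in this assay.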